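Swapping bromine for chlorine on the aromatic ring

The source may report more compounds than this note shows. Statements on the series, on what has been measured and on what is new or still open speak of the compounds shown alone.

Of the compounds shown here, three sharing one core have been measured in a functional assay on HeLa cells (Homo sapiens) for inhibition, read by sulforhodamine B assay, with a stated time of 48 h; on this read-out lower numbers stand for stronger inhibition of growth and higher numbers for weaker inhibition of growth. Compound 1 `COC(=O)[C@@]1(C)CC[C@@H]2C3=C1CC[C@@H](C)[C@]3(C)C[C@@H]1c3ccccc3N[C@H]21` gives 19000 nM. Compound 2 `COC(=O)[C@@]1(C)CC[C@@H]2C3=C1CC[C@@H](C)[C@]3(C)C[C@@H]1c3cc(C)ccc3N[C@H]21` gives 18000 nM, and compound 3 `COC(=O)[C@@]1(C)CC[C@@H]2C3=C1CC[C@@H](C)[C@]3(C)C[C@@H]1c3cc(Br)ccc3N[C@H]21` gives 25000 nM. Compound 3 has the highest of the three numbers, yet a 1.3-fold higher number from compound 1 to compound 3 (0.12 log units; within the scatter) and a 1.4-fold higher number from compound 2 to compound 3 (0.14 log units; within the scatter) both lie within the scatter, so the three cannot be ordered. Compound 4 `COC(=O)[C@@]1(C)CC[C@@H]2C3=C1CC[C@@H](C)[C@]3(C)C[C@@H]1c3cc(Cl)ccc3N[C@H]21` differs from compound 3 by chloro in place of bromo on an aromatic carbon. The two steps that put a bromo onto this carbon, a 1.3-fold higher number from compound 1 to compound 3 (0.12 log units; within the scatter) and a 1.4-fold higher number from compound 2 to compound 3 (0.14 log units; within the scatter), changed nothing beyond the scatter, and nothing here separates one halogen from another. Compound 4 is therefore expected to stay close to compound 3, with an expected step of a 1.1-fold lower number from compound 3 to compound 4 (0.06 log units; within the scatter) and an estimated value of 22000 nM, within the range 11000 nM to 45000 nM.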

Compound 4, concentration for 50% growth inhibition: 23000 nM
Compound 4: the middle estimate sits 1.0-fold (0.02 log units) below what was measured, within the range that was stated.
By their numbers in this assay, from the lowest: compounds 2, 1, 4 and 3 (each within the scatter of the next).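

Chloro in place of bromo on this aromatic carbon gives no separation (a 1.1-fold lower number from compound 3 to compound 4 (0.04 log units; within the scatter)). Chloro also stays within the scatter of the unsubstituted compound (a 1.2-fold higher number from compound 1 to compound 4 (0.08 log units; within the scatter)) and of the methyl compound (a 1.3-fold higher number from compound 2 to compound 4 (0.11 log units; within the scatter)), so in this assay hydrogen, methyl, bromo and chloro on this carbon cannot be told apart, and a second halogen now confirms this. No measurement at hand explains this flat result. Going by these compounds, whether an amine or a carboxylic acid on this carbon would stand apart from these four remains open. So does whether other places on this ring are equally indifferent.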